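The compounds below may be only part of what the source reports. "The series", "measured", "known", "first", "only" and "open" are said of these compounds alone.

Measured so far:
compound 1, `CCOC(=O)C1=C(C)NC(COC(C)=O)=C(C(=O)OCC)C1c1cccc([N+](=O)[O-])c1`, in a functional assay on HEK293 cells for antagonist activity at Voltage-dependent L-type calcium channel subunit alpha-1C (Oryctolagus cuniculus), read by FLIPR (on this read-out lower numbers stand for stronger inhibition and higher numbers for weaker inhibition), gives 10 nM
compound 2, `C=C(C)CCOC(=O)C1=C(C)NC(C)=C(C(=O)OC)C1c1cccc([N+](=O)[O-])c1`, in this assay gives 23 nM

Of the two numbers, compound 2 carries the higher one; its nearest neighbour is compound 1, whose lower number sits at a distance beyond the usual scatter. The two measured compounds differ from each other in more than one place, so no single structural step connects them and nothing can be said about the cause of that gap.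

Compound 3, `COC(=O)C1=C(C)NC(C)=C(C(=O)OCCOCc2ccccc2)C1c1cccc([N+](=O)[O-])c1`, is not yet measured. It differs from compound 2 in one place: benzyloxy in place of 1-methylethenyl on a saturated chain carbon, two bonds along the chain from an oxygen next to a carbonyl group. Nothing measured in this series speaks directly to such an exchange, so only a modest shift is expected in this assay from compound 2 to compound 3, a 1.5-fold lower number from compound 2 to compound 3 (0.19 log units; within the scatter), leaning toward a lower number but not clearly beyond the scatter. Compound 3 is therefore estimated at 15 nM, with a plausible range from 4 nM to 60 nM.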

Compound 3, half-maximal inhibitory concentration: 9 nM
Estimate against measurement, compound 3: 1.7-fold (0.22 log units) above; low and high end bracket the measured number.
By their numbers in this assay, from the lowest: compounds 3 and 1 (each within the scatter of the next); then compound 2.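

In this assay, going by these compounds alone, this position gives the first single-place comparison: benzyloxy in place of 1-methylethenyl yields a 2.6-fold lower number from compound 2 to compound 3 (0.41 log units; beyond the scatter), and the change lies beyond the usual scatter. The position therefore accepts the larger group, with 8 heavy atoms against 3 and a six-membered aromatic ring of carbon only, with no loss of inhibition on this read-out. Nothing measured here accounts for the step.

Going by these compounds, the change brings in the aromatic ring and the chain oxygen together, so which of the two goes with the lower number stays open. A 2-methoxyethyl chain, which keeps the oxygen without the ring, and a 3-phenylpropyl chain, which keeps the ring without the oxygen, would separate them, while a tertiary amine at the chain end would extend the comparison to another kind of group.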